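Fluoro to Chloro: Expected Effect on Cell Toxicity

The compounds below may be only part of what the source reports. "The series", "measured", "known", "first", "only" and "open" are said of these compounds alone.

Compound 1 `Cc1cn(C2CCN(Cc3cccc(Oc4ccccc4)n3)CC2)c(=O)[nH]c1=O`: in an ADME assay on MRC5 cells (Homo sapiens) for cytotoxicity, read by fluorescence and resazurin assay, with a stated time of 3 days (a lower number here means a stronger inhibitor, a higher number a weaker inhibitor), compound 1 gives > 64000 nM, a limit.
Compound 2 `Cc1cn(C2CCN(Cc3cccc(Oc4cccc(F)c4)c3)CC2)c(=O)[nH]c1=O`: in this assay compound 2 gives > 64000 nM, a limit.
Compound 3 `Cc1cn(C2CCN(Cc3cncc(Oc4cccc(OC(F)(F)F)c4)c3)CC2)c(=O)[nH]c1=O`: in this assay compound 3 gives > 64000 nM, a limit.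

Compound 2 sits at the limit of this assay, and so do the other two: the limit of > 64000 nM in this assay, at which 3 of the 3 values shown sit. No number separates any of them. Compound 4 `Cc1cn(C2CCN(Cc3cccc(Oc4cccc(Cl)c4)c3)CC2)c(=O)[nH]c1=O` differs from compound 2 by chloro in place of fluoro on an aromatic carbon. Among the compounds with values here, no measured pair shows what such a change does here. With every shown value resting at the limit, the step from compound 2 to compound 4 in this assay is expected to be none beyond the scatter, a step that the limit leaves unreadable from compound 2 to compound 4. Compound 4 is therefore estimated at 100000 nM, within 40000 nM to 300000 nM, most likely again reported only as a limit.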

Compound 4, half-maximal inhibitory concentration: 21000 nM
Beside the measured number, compound 4's estimate is 4.8-fold (0.68 log units) above it, and the stated range ends above it.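

In this assay chloro in place of fluoro on this aromatic carbon gives an at least 3.0-fold lower number from compound 2 to compound 4 (0.48 log units; beyond the scatter) and yields the only measured number among the compounds shown. A one-atom change on the phenoxy ring can therefore move the cytotoxicity reading beyond the scatter. The true step may be larger, because compound 2 carries only a limit: the limit of > 64000 nM in this assay, at which 3 of the 4 values shown sit.

On these data alone, whether a methyl, a nitrile or an amine at this place would shift the reading remains open. So does whether chloro would act alike on the cores of compound 1 and compound 3.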